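A Bromo Substituent Added to a Coumarin-Bearing Series

This account rests on a few compounds, and the source may have more. Where it says the series, first, only, none or still open, it means among the compounds named here.

Of the compounds shown here, two have been measured in a functional assay on HT-29 cells (Homo sapiens) for cytotoxicity, read by sulforhodamine B assay; on this read-out lower numbers stand for stronger inhibition of growth and higher numbers for weaker inhibition of growth. Compound 1 `O=c1oc2ccccc2cc1-c1cn2nc(-c3c([O-])[o+]nn3-c3ccc(Cl)cc3)sc2n1` gives 4 ug/mL, and compound 2 `COc1ccc(-n2n[o+]c([O-])c2-c2nn3cc(-c4cc5ccccc5oc4=O)nc3s2)cc1` gives 3.14 ug/mL. The two differ only by a methoxy in place of chloro on an aromatic carbon, and that step, a 1.3-fold lower number from compound 1 to compound 2 (0.11 log units; within the scatter), lies within the usual scatter. Compound 1 therefore holds the highest of the two numbers, but its neighbour compound 2 stands so close that no order between them can be claimed.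

Compound 3 `O=c1oc2ccc(Br)cc2cc1-c1cn2nc(-c3c([O-])[o+]nn3-c3ccc(Cl)cc3)sc2n1` has not yet been measured. It is compound 1 with one change: bromo in place of hydrogen on an aromatic carbon. Going by the values given here, no measured step touches that part of the shared core; the only step known concerns a different ring. There is thus no basis for expecting a shift in this assay beyond the scatter in either direction, and the estimate for compound 3 is anchored on the number of compound 1, 4 ug/mL. The expected step of no change at the digits printed from compound 1 to compound 3 (within the scatter) is small. Compound 3 is expected to give 4 ug/mL, within a range from 1.5 ug/mL to 11 ug/mL.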

Compound 3, concentration for 50% growth inhibition: 5.25 ug/mL
Estimate against measurement, compound 3: 1.3-fold (0.12 log units) below, within the range that was stated.
By their numbers in this assay, from the lowest: compounds 2, 1 and 3 (each within the scatter of the next).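

Going by these compounds alone, the only earlier step concerned a different ring, so this result is the first look at the six-membered aromatic ring of carbon only that is part of a fused system of two rings. In this assay, putting bromo in place of hydrogen on this ring gives a 1.3-fold higher number from compound 1 to compound 3 (0.12 log units; within the scatter). At this one position, then, adding a single bromine atom, which brings no ring, no net charge and no hydrogen-bond donors or acceptors, leaves the number indistinguishable from that of the parent compound, and nothing available explains this result or shows what it would take to move the number here.

Going by these compounds, a single substituent says little about the position as a whole, so it remains open whether an amine or a carboxylic acid on the same carbon, either of which would bring hydrogen-bond donors and acceptors, would shift growth inhibition beyond the scatter. It is also open whether bromo would behave the same way alongside the methoxy group of compound 2, since the compounds shown pair it only with the chloro group.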